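The source may hold more compounds than are shown below. What is called first, only, known or untested is meant among the compounds shown, and "the series" means these compounds.

In a functional assay on HeLa cells (Homo sapiens) for antiproliferative activity, with a stated time of 24 h (on this read-out higher numbers stand for weaker inhibition and lower numbers for stronger inhibition), compound 1 `NC(=O)c1c(NC(=O)c2ccccc2Br)sc2c1CCN(C(=S)Nc1ccccc1Cl)C2` gives 46900 nM and stands, within the scatter, together with compound 3 `NC(=O)c1c(NC(=O)c2cccc([N+](=O)[O-])c2)sc2c1CCN(C(=S)Nc1ccccc1Cl)C2`, which gives 40300 nM. For compound 2 `NC(=O)c1c(NC(=O)c2ccccc2I)sc2c1CCN(C(=S)Nc1ccccc1Cl)C2` the assay reports only a limit, > 50000 nM. The steps of a 1.2-fold lower number from compound 1 to compound 3 (0.07 log units; within the scatter) and an at least 1.0-fold higher number from compound 1 to compound 2 (0.02 log units; that floor lies within the scatter) both remain within the scatter, the latter sitting at the limit of > 50000 nM in this assay, at which 1 of the 3 values shown sits. Compound 4 `Cc1ccccc1NC(=S)N1CCc2c(sc(NC(=O)c3ccccc3Br)c2C(N)=O)C1` differs from compound 1 by methyl in place of chloro on an aromatic carbon. Both measured steps exchange the aryl on the carbonyl carbon and leave the (2-chlorophenyl)amino side untouched, so none of them bears directly on this change; given how small a 1.2-fold lower number from compound 1 to compound 3 (0.07 log units; within the scatter) and an at least 1.0-fold higher number from compound 1 to compound 2 (0.02 log units; that floor lies within the scatter) were, the step of a 1.0-fold lower number from compound 1 to compound 4 (0.02 log units; within the scatter) is expected to stay within the scatter. Compound 4 is therefore estimated at 45000 nM, with a range from 20000 nM to 90000 nM.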

Compound 4, half-maximal inhibitory concentration: > 50000 nM
Compound 4: a limit, no number (the forecaster's own chance of this, stated with the estimate: 40%); at least 1.1-fold (0.04 log units) between middle value and limit.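

The step of an at least 1.0-fold higher number from compound 1 to compound 4 (0.02 log units; that floor lies within the scatter) is the only one shown on the (2-chlorophenyl)amino side, so it is the first reading of a change on this aromatic carbon, ortho to a large group. Compound 4 gives only a limit in this assay, > 50000 nM, so the size of its difference from compound 1 cannot be read. Swapping chloro for methyl here brought no clear strengthening, and the limit now holds a further compound: the limit of > 50000 nM in this assay, at which 2 of the 4 values shown sit.

On these data alone, whether an amine or a carboxylic acid on this aromatic carbon would give a clearly lower number stays open. So does whether methyl here would behave alike with 3-nitrophenyl on the carbonyl carbon.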